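Piperidin-1-yl in place of the amine side group

A few compounds are considered here, and "the series" means these few. Any claim that something is new, unique, unknown or untested is made for them only; others in the source may bear on it.

For the measured compounds named here, compound 2 `CCN(Cc1ccncc1)c1cccc(C(=O)N2CCc3ccc(OS(N)(=O)=O)cc3C2)c1` is one of two compounds measured in an assay on HEK293 cells for inhibition of Steryl-sulfatase (Homo sapiens), tested at 0.1 uM; on this read-out higher numbers stand for a stronger effect at the one concentration tested and lower numbers for a weaker effect. Compound 2 gives 33.3%, the highest of the two numbers, with compound 1 `CCN(Cc1ccc(Br)cc1)c1cccc(C(=O)N2CCc3ccc(OS(N)(=O)=O)cc3C2)c1` nearest at 24.2%. Going by the values given here, the only measured step, a number 9.1 percentage points higher from compound 1 to compound 2 (within the scatter), lies within the scatter. Compound 3 `NS(=O)(=O)Oc1ccc2c(c1)CN(C(=O)c1cccc(N3CCCCC3)c1)CC2` has not yet been measured. It differs from compound 2 in one place: piperidin-1-yl in place of ethyl((pyridin-4-yl)methyl)amino on an aromatic carbon. The measured step concerns a different kind of exchange, pyridin-4-yl for 4-bromophenyl on a saturated chain carbon bound to a nitrogen on an aromatic ring, and it was small, within the scatter. It bears only loosely on the present change, and the data give no ground to expect a step beyond the scatter in either direction in this assay. Compound 3 is therefore expected to give about 28%, between 8% and 48%. The expected step of a number 5.3 percentage points lower from compound 2 to compound 3 (within the scatter) is estimated to be small.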

Compound 3, a percentage reported as inhibition, at one concentration (the size of the read-out at that concentration, not a potency): 1%
Beside the measured number, compound 3's estimate is 27 percentage points above it; the measured number lies below the stated range.
By their numbers in this assay, from the lowest: compound 3; then compounds 1 and 2 (each within the scatter of the next).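

In this assay, piperidin-1-yl on this aromatic carbon gives a number 32.3 percentage points lower from compound 2 to compound 3 (beyond the scatter) in place of ethyl((pyridin-4-yl)methyl)amino, and a number 23.2 percentage points lower from compound 1 to compound 3 (beyond the scatter) in place of (4-bromobenzyl)(ethyl)amino. The earlier exchange of 4-bromophenyl for pyridin-4-yl stayed within the scatter, whereas these two steps show that the read-out at this position does respond to the group present, with both open-chain amines carrying an aromatic ring standing clear of the piperidin-1-yl compound. Nothing available explains this difference.

The compounds shown leave open whether the aromatic ring, the ethyl group or the open chain on the nitrogen accounts for the gap. A diethylamino group or a 4-benzylpiperidin-1-yl group at this position would begin to separate these parts.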